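Swapping Nitro for Amino in Two Related Series

The source may hold more compounds than are shown below. What is called first, only, known or untested is meant among the compounds shown, and "the series" means these compounds.

Four compounds are compared in a functional assay on HeLa cells (Homo sapiens) for antiproliferative activity, read by MTT assay, with a stated time of 72 h; a lower number here means a stronger inhibitor, a higher number a weaker inhibitor. Compound 1 `COc1ccc(OC(=O)c2cc(OC)c(OC)c(OC)c2)cc1[N+](=O)[O-]` and compound 2 `COc1ccc(OC(=O)c2cc(OC)c(OC)c(OC)c2)cc1N` share a core built around an ester, while compound 3 `COc1ccc(C(=O)Nc2cc(OC)c(OC)c(OC)c2)cc1[N+](=O)[O-]` and compound 4 `COc1ccc(C(=O)Nc2cc(OC)c(OC)c(OC)c2)cc1N` share a core built around an amide. The difference between the two cores is not broken down here.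

In this assay compound 1 gives > 100000 nM, which is a limit of the assay rather than a number. Compound 2 likewise gives > 100000 nM, again a limit. The change between them, (amino in place of nitro on an aromatic carbon), made a step that the two limits leave unreadable from compound 1 to compound 2, and because of the limit of > 100000 nM in this assay, at which 2 of the 3 values shown sit, no size can be read from this pair. Within the data shown here, compound 3 gives 3700 nM, the only number among the three measured values.

Compound 4 differs from compound 3 by amino in place of nitro on an aromatic carbon, the same change as between the first two compounds. With no readable size from the earlier pair, the expectation rests on the measured value of compound 3, 3700 nM, and the step from compound 3 to compound 4 is expected to be small, a 1.2-fold lower number from compound 3 to compound 4 (0.09 log units; within the scatter). Compound 4 is therefore expected to give about 3000 nM, with a likely span from 500 nM to 20000 nM.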

Compound 4, half-maximal inhibitory concentration: > 100000 nM
Compound 4 gave a limit, no number (the forecaster's own chance of this, stated with the estimate: 10%); at least 33-fold (1.52 log units) between middle value and limit.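

In this assay, amino in place of nitro on an aromatic carbon of the amide core gave an at least 27-fold higher number from compound 3 to compound 4 (1.43 log units; beyond the scatter), so in this core the nitro compound is clearly the more active of the two. Compound 4 gives > 100000 nM, which is a limit of the assay and not a number. The same change on the ester core of compound 1 and compound 2 cannot be read, so these compounds neither show that the effect carries from one core to the other nor show that it fails to, and the reason is this: the limit of > 100000 nM in this assay, at which 3 of the 4 values shown sit.

The compounds shown leave open whether the activity of compound 3 depends on the nitro group itself, or whether another group in that place on the amide core, such as a nitrile, a methyl or a carboxylic acid, would serve as well. They also leave open how any such group would behave on the ester core, where neither of the two compounds gives a number.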